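Compound 3 in the low-cytotoxicity series: working notes

The source may report more compounds than this note shows. Statements on the series, on what has been measured and on what is new or still open speak of the compounds shown alone.

Measured in an ADME assay on BJ cells (Homo sapiens) for cytotoxicity, with a stated time of 72 h; a lower number here means that less compound is needed, a higher number that more compound is needed for the effect:
- compound 1 (`COc1cc2nc(C)nc(-n3nc(-c4ccccn4)nc3N)c2cc1OC`): > 13000 nM
- compound 2 (`COc1cc2ncnc(-n3nc(-c4ccccn4)nc3N)c2cc1OCc1ccccc1`): > 27000 nM

Compound 1 gives a limit of > 13000 nM in this assay and no number. Compound 2 also stands at a limit, > 27000 nM, so its position in this assay is not fixed by a number. Among the measured compounds shown here, no step between measured compounds is available.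

The next compound is compound 3 (`COc1cc2ncnc(-n3nc(-c4ccccn4)nc3N)c2cc1OCCCCNC(=O)OC(C)(C)C`). Its difference from compound 2 is 3-((tert-butoxycarbonyl)amino)propyl in place of phenyl on a saturated chain carbon bound to an oxygen on an aromatic ring. In words, 3-((tert-butoxycarbonyl)amino)propyl stands in place of phenyl on a saturated chain carbon bound to an oxygen on an aromatic ring. Cut one bond further out, the same difference reads benzyl to 4-((tert-butoxycarbonyl)amino)butyl.

The expectation rests on compound 2 with its limit of > 27000 nM and is for no change beyond the scatter in this assay, in neither direction. The expected step is an at least 1.0-fold lower number from compound 2 to compound 3 (0.03 log units; that floor lies within the scatter), an estimate that stays within the scatter. For compound 3 the estimated value is 25000 nM, with an expected range of 9000 nM to 60000 nM.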

Compound 3, half-maximal effective concentration: > 7000 nM
Compound 3 ended at the assay's limit; the forecaster's own chance of this, stated with the estimate: 70%; the middle value is on the limit's open side.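

In this assay compound 3 gives > 7000 nM, a limit and not a number. Among the compounds shown here, compound 2 also gives a limit, > 27000 nM, so no step from compound 2 to compound 3 can be read. The compounds shown leave open whether 4-((tert-butoxycarbonyl)amino)butyl in place of benzyl changes the half-maximal effective concentration at all.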